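A few compounds are considered here, and "the series" means these few. Any claim that something is new, unique, unknown or untested is made for them only; others in the source may bear on it.

Compound 1 `Cc1ccc(N(C(=O)c2cccc(C)c2)C(=S)OCCN2C(=O)c3ccccc3C2=O)cc1`: > 100000 nM (a limit)
Compound 2 `Cc1ccc(N(C(=O)c2c(F)cccc2F)C(=S)OCCN2C(=O)c3ccccc3C2=O)cc1`: 65000 nM

Going by the values given here, in an ADME assay on MT4 cells (Homo sapiens) for cytotoxicity, read by MTT assay (on this read-out lower numbers stand for higher toxicity in this test and higher numbers for lower toxicity in this test), compound 2 gives 65000 nM, the only true number available so far. Compound 1 gives > 100000 nM, which is a limit of the assay and not a number (the limit of > 100000 nM in this assay, at which 1 of the 2 values shown sits).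

Compound 3 `Cc1ccc(N(C(=O)c2cccc(Cl)c2Cl)C(=S)OCCN2C(=O)c3ccccc3C2=O)cc1` is still to be measured. It keeps the core of compound 2 and changes one group: 2,3-dichlorophenyl in place of 2,6-difluorophenyl on a carbonyl carbon. In words, 2,3-dichlorophenyl replaces 2,6-difluorophenyl on a carbonyl carbon.

Among the compounds with values here, only one measured step bears on this, since it is also a swap of groups on that carbonyl carbon: an at least 1.5-fold lower number from compound 1 to compound 2 (0.18 log units; that floor lies within the scatter). It offers only a floor, so it gives no firm guide to size or direction, and no change beyond the scatter is expected. The expected change is a 1.2-fold lower number from compound 2 to compound 3 (0.07 log units; within the scatter). For compound 3, the estimate is 55000 nM, with an expected range of 20000 nM to 100000 nM.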

Compound 3, half-maximal cytotoxic concentration: 35000 nM
Beside the measured number, compound 3's estimate is 1.6-fold (0.20 log units) above it; measured number inside the range.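

In this assay, changing the group on the carbonyl carbon now gives a step that lies beyond the scatter, so this place in the molecule can shift the number: an at least 2.8-fold lower number from compound 1 to compound 3 (0.45 log units; beyond the scatter). Between the two phenyl groups that carry halogens, no change can be told from the scatter: a 1.9-fold lower number from compound 2 to compound 3 (0.27 log units; within the scatter). Compound 1 stands at a limit and not at a number, so the first step gives only a floor: the limit of > 100000 nM in this assay, at which 1 of the 3 values shown sits.

The compounds shown cannot separate what the methyl group leaving and the two chlorine atoms entering each contribute to that first step. As far as these compounds go, it also remains open how the number would respond to a phenyl group with a single chlorine, or to one carrying an amine or a carboxylic acid, on this carbonyl carbon.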